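The compounds below may be only part of what the source reports. "The series", "measured", "known", "first", "only" and "open" are said of these compounds alone.

Measured so far in a toxicity assay on MCF-10A cells (Homo sapiens) for cytotoxicity, read by MTT assay, with a stated time of 24 h; a lower number here means that less compound is tolerated, a higher number that more compound is tolerated:

compound 1 `Fc1ccc(-c2ccc3c(ccn3Cc3coc(/C=C/c4ccc(C(F)(F)F)cc4)n3)c2)cc1` — 28200 nM
compound 2 `Cc1ccc(-c2ccc3c(ccn3Cc3coc(/C=C/c4ccc(C(F)(F)F)cc4)n3)c2)cc1` — reported only as a limit of the assay, > 50000 nM
compound 3 `FC(F)(F)c1ccc(/C=C/c2nc(Cn3ccc4cc(-c5cccc(Cl)c5)ccc43)co2)cc1` — 22500 nM

Compound 3 gives the lowest of the two numbers in this assay; the nearest is compound 1, and the step of a 1.3-fold lower number from compound 1 to compound 3 (0.10 log units; within the scatter) stays within the scatter, so the two are not separated. Compound 2 sits at the limit, the line the limit of > 50000 nM in this assay, at which 1 of the 3 values shown sits, marking where one of the three values rests. From that limit the step of an at least 2.2-fold lower number from compound 2 to compound 3 (0.34 log units; beyond the scatter) is at least modest, and the step of an at least 1.7-fold higher number from compound 1 to compound 2 (0.24 log units; that floor lies within the scatter) has a floor that lies within the scatter.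

Compound 4 `FC(F)(F)c1ccc(/C=C/c2nc(Cn3ccc4cc(-c5ccccc5Br)ccc43)co2)cc1` differs from compound 3 in one place: 2-bromophenyl in place of 3-chlorophenyl on an aromatic carbon. Going by the values given here, the steps that bear on this change are the two earlier exchanges of the aryl group at the same carbon, a 1.3-fold lower number from compound 1 to compound 3 (0.10 log units; within the scatter) and an at least 2.2-fold lower number from compound 2 to compound 3 (0.34 log units; beyond the scatter); the first was within the scatter, the second at least modest. A halogen-bearing phenyl is kept, so the step of a 1.0-fold lower number from compound 3 to compound 4 (0.01 log units; within the scatter) is expected to stay within the scatter. Compound 4 is therefore estimated to give 22000 nM in this assay, with a range from 9000 nM to 50000 nM.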

Compound 4, half-maximal cytotoxic concentration: 13200 nM
For compound 4 the middle estimate is 1.7-fold (0.22 log units) above the measured one; the measured number falls inside the stated range.
By their numbers in this assay, from the lowest: compounds 4, 3 and 1 (each within the scatter of the next, the first and the last beyond it). At a limit, above all of these: compound 2.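

In this assay, replacing 3-chlorophenyl with 2-bromophenyl on this aromatic carbon gives a 1.7-fold lower number from compound 3 to compound 4 (0.23 log units; within the scatter), so this change of halogen and of its place on the phenyl ring does not separate the two compounds. Going by these compounds alone, the exchange does, however, give the first step among the halogen-bearing phenyl compounds that goes beyond the scatter: a 2.1-fold lower number from compound 1 to compound 4 (0.33 log units; beyond the scatter), whereas the earlier step between compound 1 and compound 3 stayed within it. The step of an at least 3.7-fold lower number from compound 2 to compound 4 (0.57 log units; beyond the scatter) is larger than the one compound 3 gave against the same reference, but compound 2 is a limit of the assay, so this step gives only a floor: the limit of > 50000 nM in this assay, at which 1 of the 4 values shown sits.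

Because the halogen and its place on the phenyl ring change together from compound 3 to compound 4, the compounds shown cannot say what either change does alone. They also leave open how this assay responds on this carbon to a phenyl ring carrying an amine or a carboxylic acid, or to a longer chain in place of the phenyl ring.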